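From 1-(hydroxymethyl)ethyl to 1-(hydroxymethyl)cyclopropyl on the amide

The source may hold more compounds than are shown below. What is called first, only, known or untested is meant among the compounds shown, and "the series" means these compounds.

Compound 1 `CCN(CC)CCNC(=O)c1ccc(C(CC)(CC)c2ccc(OCS(=O)(=O)c3ccccc3)c(C)c2)n1CC`: 7130 nM
Compound 2 `CCn1c(C(=O)N[C@@H](C)CO)ccc1C(CC)(CC)c1ccc(OCS(=O)(=O)c2ccccc2)c(C)c1`: 9520 nM
Compound 3 `CCn1c(C(=O)N[C@H](C)CO)ccc1C(CC)(CC)c1ccc(OCS(=O)(=O)c2ccccc2)c(C)c1`: 7790 nM

All three compounds were tested in a functional assay on PC-3 cells (Homo sapiens) for antiproliferative activity, read by MTT assay, with a stated time of 24 h (a lower number here means a stronger inhibitor, a higher number a weaker inhibitor), and their numbers lie close together. Compound 3, at 7790 nM, cannot be ranked against the other two, since a 1.1-fold higher number from compound 1 to compound 3 (0.04 log units; within the scatter) and a 1.2-fold lower number from compound 2 to compound 3 (0.09 log units; within the scatter).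

Compound 4 `CCn1c(C(=O)NC2(CO)CC2)ccc1C(CC)(CC)c1ccc(OCS(=O)(=O)c2ccccc2)c(C)c1` keeps the shared core and alters only the group on the amide-type nitrogen: 1-(hydroxymethyl)cyclopropyl in place of 1-(hydroxymethyl)ethyl on an amide-type nitrogen. Two kinds of measured step bear on this change. Replacing the whole 2-(diethylamino)ethyl group at that nitrogen gave a 1.3-fold higher number from compound 1 to compound 2 (0.13 log units; within the scatter), and reversing the stereocentre in that side chain gave a 1.2-fold lower number from compound 2 to compound 3 (0.09 log units; within the scatter). Going by the values given here, neither step rises above the scatter, although no compound with the three-membered ring has yet been measured. A step beyond the scatter is therefore not expected, and the estimated change is small: a 1.0-fold higher number from compound 3 to compound 4 (0.01 log units; within the scatter). For compound 4 the expected value in this assay is 8000 nM, with an estimated range of 4500 nM to 14000 nM.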

Compound 4, half-maximal inhibitory concentration: 3560 nM
For compound 4 the middle estimate is 2.2-fold (0.35 log units) above the measured one; the whole stated range lies above it.
By their numbers in this assay, from the lowest: compounds 4, 1, 3 and 2 (each within the scatter of the next, the first and the last beyond it).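

Earlier changes at this amide-type nitrogen all stayed within the scatter, so the position seemed insensitive to what was placed there, but in this assay the 1-(hydroxymethyl)cyclopropyl group moves the number beyond it: a 2.2-fold lower number from compound 3 to compound 4 (0.34 log units; beyond the scatter) and a 2.7-fold lower number from compound 2 to compound 4 (0.43 log units; beyond the scatter). The change reads the same way against both drawn forms of 1-(hydroxymethyl)ethyl, so the outcome does not rest on one configuration of that group: the fact that compounds 2 and 3 differ only in the configuration as drawn. Against the 2-(diethylamino)ethyl group the gap is smaller, a 2.0-fold lower number from compound 1 to compound 4 (0.30 log units; within the scatter), so compound 4 cannot be ranked ahead of compound 1.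

As far as these compounds go, what remains open is whether the three-membered ring itself matters, which a 2-hydroxy-1,1-dimethylethyl group, having no ring, could help to separate. A 1-(hydroxymethyl)cyclobutyl group would show whether a larger ring at this nitrogen reads the same way.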